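This account rests on a few compounds, and the source may have more. Where it says the series, first, only, none or still open, it means among the compounds named here.

Two compounds share one core and are measured in a functional assay on UoC-B1 cells (Homo sapiens) for antiproliferative activity, with a stated time of 72 h; a lower number here means that less compound is needed, a higher number that more compound is needed for the effect: compound 1 (`C=CCNC(=O)n1c(-c2ccc(OC)cc2)cc(=O)c2c(OC)cc(OC)cc21`) and compound 2 (`COc1cc(OC)c2c(=O)cc(C(=O)Nc3cccc(N4CCCC4)c3)[nH]c2c1`). For compound 1 the outcome is "not determined" (no result reported). For compound 2 the result is only a limit of the assay, > 58600 nM. So compound 2 stands at the limit of > 58600 nM in this assay, at which 1 of the 2 values shown sits, and no single number for any compound in this assay is available beside it.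

Compound 3 (`COc1cc(OC)c2c(=O)cc(C(=O)Nc3cccc(-c4nccs4)c3)[nH]c2c1`) is the next compound to be tested in this assay. It differs from compound 2 in one place: 1,3-thiazol-2-yl in place of pyrrolidin-1-yl on an aromatic carbon. Among the measured compounds shown here, no step between two measured compounds exists here to guide the expectation, so it rests on compound 2 alone. Compound 3 is expected to remain near the limit, with an estimate of 60000 nM, ranging from 12000 nM to 250000 nM. The expected step is a step that the limit leaves unreadable from compound 2 to compound 3, which is no change beyond the scatter.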

Compound 3, half-maximal effective concentration: > 54000 nM
Compound 3: a limit, no number (the forecaster's own chance of this, stated with the estimate: 60%); the middle value does not contradict the limit.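

Compound 2 and compound 3 each give only a limit in this assay, not a number, so no step can be read for 1,3-thiazol-2-yl in place of pyrrolidin-1-yl. The compounds shown leave open whether any compound on this shared core gives a single number.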